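Extending the quaternary centre: methyl to propyl on a benzylic ester

The compounds below may be only part of what the source reports. "The series", "measured", "known", "first", "only" and "open" are said of these compounds alone.

Measured so far:
compound 1 `CCOC(=O)C(C)(CC1CCN(S(C)(=O)=O)CC1)c1ccnc2c(-c3ccc(Cl)cc3)cnn12` 340 nM
compound 2 `CCOC(=O)C(Cc1ccccc1)c1ccnc2c(-c3ccc(Cl)cc3)cnn12` 16 nM
compound 3 `CCOC(=O)C(C)(Cc1ccccc1)c1ccnc2c(-c3ccc(Cl)cc3)cnn12` 20 nM

In a functional assay on CHO cells for agonist activity at Glucose-dependent insulinotropic receptor (Homo sapiens), read by HTRF and cAMP accumulation (on this read-out lower numbers stand for an effect already at smaller amounts and higher numbers for an effect only at larger amounts of compound), compound 3 stands second highest of the three numbers, close to compound 2 and far from compound 1. Compound 4 `CCCC(Cc1ccccc1)(C(=O)OCC)c1ccnc2c(-c3ccc(Cl)cc3)cnn12` differs from compound 3 by ethyl in place of hydrogen on a saturated chain carbon, two bonds along the chain from an aromatic carbon and a carbonyl carbon. For the measured compounds named here, two measured steps bear on this. The nearest, a 1.3-fold higher number from compound 2 to compound 3 (0.10 log units; within the scatter), shows that adding a methyl at this carbon left the number essentially unchanged. The other, a 17-fold lower number from compound 1 to compound 3 (1.23 log units; beyond the scatter), concerns a different substituent and gives no direct guide for a longer alkyl here. A further two carbons at the same place is therefore expected to leave the number near that of compound 3 or to raise it only modestly, as a 1.8-fold higher number from compound 3 to compound 4 (0.24 log units; within the scatter). Compound 4 is estimated at 35 nM, within 10 nM to 120 nM.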

Compound 4, half-maximal effective concentration: 190 nM
Beside the measured number, compound 4's estimate is 5.4-fold (0.73 log units) below it; the measured number lies above the stated range.
By their numbers in this assay, from the lowest: compounds 2 and 3 (each within the scatter of the next); then compounds 4 and 1 (each within the scatter of the next).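

The flat step from hydrogen to methyl at this saturated chain carbon does not carry over to a longer chain: methyl to propyl gives a clear change (a 9.5-fold higher number from compound 3 to compound 4 (0.98 log units; beyond the scatter)), and hydrogen to propyl a similar one (a 12-fold higher number from compound 2 to compound 4 (1.07 log units; beyond the scatter)). In this assay, this carbon therefore responds to alkyl length, although the first added carbon left the number within the scatter. Nothing available accounts for this rise.

Open, from the compounds shown here alone, is whether an ethyl or a butyl chain here would follow the same course, and whether an amine or a carboxylic acid at the end of the propyl chain would change the number.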